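Fluoro for hydrogen on compound 3, effect expected negligible

The source may report more compounds than this note shows. Statements on the series, on what has been measured and on what is new or still open speak of the compounds shown alone.

Three compounds of the series have been run in an assay on isolated protein for inhibition of RAC-alpha serine/threonine-protein kinase (Homo sapiens), tested at 30 uM; a lower number here means less inhibition, a higher number more inhibition at the concentration tested (going by the name of the read-out). In this assay compound 1 `Cn1cnc2c(Nc3ccccc3)ncnc21` gives 0%. In this assay compound 2 `Cn1cnc2c(Sc3ccc(F)cc3)ncnc21` gives 0%. In this assay compound 3 `c1ccc(-[n+]2c[nH]c3ncncc32)cc1` gives 0%. Compound 3 thus stands level with compounds 1 and 2 at the digits recorded; its nearest neighbour on the numbers is compound 1, with no change within the scatter, and its furthest is compound 2, again with no change within the scatter. Going by the values given here, no two measured compounds differ in a single place, so no single-point step has been measured in this assay, and the series so far shows no inhibition at all at the concentration used.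

Compound 4 `Fc1ccc(-[n+]2c[nH]c3ncncc32)cc1` is derived from compound 3 by the change (fluoro in place of hydrogen on an aromatic carbon). Among the compounds with values here, the measured compounds give no precedent for this change. The step from compound 3 to compound 4 in this assay is expected to lie within the scatter, with no preferred direction, a number 2 percentage points higher from compound 3 to compound 4 (within the scatter). Compound 4 is therefore expected to give 2% in this assay, in the range -8% to 12%.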

Compound 4, a percentage reported as inhibition, at one concentration (the size of the read-out at that concentration, not a potency): 0%
For compound 4 the middle estimate is 2 percentage points above the measured one; the range from low to high includes it.
By their numbers in this assay, from the lowest: compounds 1, 2, 3 and 4 (each within the scatter of the next).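

In this assay, fluoro in place of hydrogen on an aromatic carbon, para to a group of 9 heavy atoms, reads no change at the digits printed from compound 3 to compound 4 (within the scatter) and gives the series its first single-place step. At this position, this change therefore brings no inhibition into view at the concentration tested, with compound 3 at 0% and compound 4 at 0% as the two ends of the step. Nothing measured here bears on why the reading stays the same.

Both ends of the step sit at the same reading as compounds 1 and 2, so the series offers no measurable inhibition against which a small effect of fluoro could be seen. Going by these compounds, whether an amine, a carboxylic acid or a longer chain at this position would give any inhibition remains open.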